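A methylsulfonyl in place of methylsulfanyl

The compounds below may be only part of what the source reports. "The series", "measured", "known", "first", "only" and "open" are said of these compounds alone.

In a functional assay on the whole organism for antagonist activity, with Mus musculus as the target, in the maximal electroshock model (on this read-out lower numbers stand for an effect already at smaller amounts and higher numbers for an effect only at larger amounts of compound), compound 1 (`Cn1c(-c2cccs2)nnc1[S+](C)[O-]`) gives > 200 mg/kg, which is a limit of the assay and not a number. In this assay compound 2 (`CCSc1nnc(-c2ccccc2)n1C`) gives > 200 mg/kg, also a limit. In this assay compound 3 (`CSc1nnc(-c2cccc3ccccc23)n1C`) gives > 200 mg/kg, again a limit. For the measured compounds named here, compound 3 therefore stands with the other measured compounds at the limit of > 200 mg/kg in this assay, at which 3 of the 3 values shown sit, and no measured compound has yet given an actual dose.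

The next change leads to compound 4 (`Cn1c(-c2cccc3ccccc23)nnc1S(C)(=O)=O`), with methylsulfonyl in place of methylsulfanyl on an aromatic carbon. Going by the values given here, no step between measured compounds is available to size this change. A modest move toward smaller doses is expected, though it may stay within the usual scatter. The estimated change is an at least 1.3-fold lower number from compound 3 to compound 4 (0.12 log units; that floor lies within the scatter). The expectation stays cautious because the limit of > 200 mg/kg in this assay, at which 3 of the 3 values shown sit, is all the measurements provide, and a further report of only a limit is quite possible. For compound 4 the expected dose is 150 mg/kg, with an estimated range from 50 mg/kg to 300 mg/kg.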

Compound 4, dose for half-maximal effect: > 200 mg/kg
Compound 4: no number, only a limit; the forecaster's own chance of this, stated with the estimate: 55%; at least 1.3-fold (0.12 log units) between middle value and limit.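

For the compounds shown here, compound 3 and compound 4 both sit at a limit in this assay, so no step between them can be read: the limit of > 200 mg/kg in this assay, at which 4 of the 4 values shown sit. The compounds shown leave open whether methylsulfonyl in place of methylsulfanyl changes the dose at all, and whether any of these compounds reaches an actual dose in this assay.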